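A Furan Swap on the Most Permeable Compound

The source may report more compounds than this note shows. Statements on the series, on what has been measured and on what is new or still open speak of the compounds shown alone.

Values measured in an ADME assay for permeability, using PAMPA, with a stated time of 30 min, at pH 7.4; on this read-out higher numbers stand for higher permeability and lower numbers for lower permeability
Compound 1 (`FC(F)(F)c1cc(-c2ccc3c(NCCCNCc4ccco4)ccnc3c2)cc(C(F)(F)F)c1`) gives 237 10^-6 cm/s
Compound 2 (`COc1ccc(F)cc1CNCCCNc1ccnc2cc(Cc3ccccc3)ccc12`) gives 23 10^-6 cm/s
Compound 3 (`COc1cccc(CNCCCNc2ccnc3cc(CC(C)C)ccc23)c1O`) gives 23 10^-6 cm/s

Compound 1 stands highest of the three, and its gaps to compound 2 and compound 3 both lie beyond the scatter. Compound 4 (`COc1ccc(F)cc1CNCCCNc1ccnc2cc(-c3cc(C(F)(F)F)cc(C(F)(F)F)c3)ccc12`) keeps the core of compound 1 and changes in one place (5-fluoro-2-methoxyphenyl in place of furan-2-yl on a saturated chain carbon bound to an amine nitrogen). Going by the values given here, no pair of measured compounds shows this change alone, so its size in this assay can only be judged. A modest fall is expected, possibly none beyond the scatter. The step expected is small and downward (a 1.6-fold lower number from compound 1 to compound 4 (0.20 log units; within the scatter)). For compound 4 the estimated value is 150 10^-6 cm/s (range 50 10^-6 cm/s to 400 10^-6 cm/s).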

Compound 4, apparent permeability in the ADME assay: 237 10^-6 cm/s
Compound 4: middle estimate off by 1.6-fold (0.20 log units), on the low side, within the range that was stated.
By their numbers in the ADME assay, from the lowest: compounds 2 and 3 (each within the scatter of the next); then compounds 1 and 4 (each within the scatter of the next).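

Going by these compounds alone, compound 4 supplies the only pair here that isolates this change: in the ADME assay the exchange of furan-2-yl for 5-fluoro-2-methoxyphenyl, on a saturated chain carbon bound to an amine nitrogen, shows no change at the digits printed from compound 1 to compound 4 (within the scatter), with compound 1 at 237 10^-6 cm/s and compound 4 at 237 10^-6 cm/s, so this position accepts the larger group with no step in that read-out. In a physicochemical assay for acid dissociation, the same change shows no change at the digits printed from compound 1 to compound 4 (within the scatter) as well, with compound 1 at 9.47 and compound 4 at 9.47. No evidence here accounts for either result.

Going by these compounds, whether a carboxylic acid or a longer chain at this place would read the same remains open.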